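Indole series, thyroid hormone receptor beta binding: chloro for methyl

The source may report more compounds than this note shows. Statements on the series, on what has been measured and on what is new or still open speak of the compounds shown alone.

Measured so far:
compound 1 `Cc1cc2cc(OCC(=O)O)ccc2n1Cc1ccc(O)c(C(C)C)c1` — 1.12 nM
compound 2 `Cc1cc(OCC(=O)O)cc2cc(C)n(Cc3ccc(O)c(C(C)C)c3)c12` — 0.14 nM

In an assay on HeLa cells for displacement of a labelled ligand from thyroid hormone receptor beta (Homo sapiens) (on this read-out higher numbers stand for weaker inhibition and lower numbers for stronger inhibition), compound 2 gives 0.14 nM, the lowest of the two numbers in hand. For the measured compounds named here, the nearest is compound 1, which in this assay gives 1.12 nM; the single measured step, an 8.0-fold lower number from compound 1 to compound 2 (0.90 log units; beyond the scatter), lies beyond the scatter and is the only change so far at this position of the shared core.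

Compound 3 `Cc1cc2cc(OCC(=O)O)cc(Cl)c2n1Cc1ccc(O)c(C(C)C)c1` is the next point. It differs from compound 2 by chloro in place of methyl on an aromatic carbon. Going by the values given here, no measured pair exchanges chloro for methyl, so the only step that bears on it is an 8.0-fold lower number from compound 1 to compound 2 (0.90 log units; beyond the scatter), which shows what a single heavy atom at this site did against hydrogen. Chloro, like methyl, is one heavy atom without donors or acceptors; the exchange between the two is therefore expected to move this assay little, if at all, and any step is expected to stay within the scatter.

Compound 3 is accordingly estimated at 0.2 nM, with a range of 0.06 nM to 0.7 nM, meaning an expected step of a 1.4-fold higher number from compound 2 to compound 3 (0.15 log units; within the scatter).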

Compound 3, inhibition constant: 0.04 nM
Estimate against measurement, compound 3: 5.0-fold (0.70 log units) above, outside the stated range (below it).
By their numbers in this assay, from the lowest: compound 3; then compound 2; then compound 1.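

In this assay, chloro and methyl are not interchangeable at this aromatic carbon, even though each is a single heavy atom with no hydrogen-bond donors or acceptors: the exchange gives a 3.5-fold lower number from compound 2 to compound 3 (0.54 log units; beyond the scatter). The position therefore responds to which atom is placed there, not only to whether hydrogen has been replaced, and the step for chloro, a 28-fold lower number from compound 1 to compound 3 (1.45 log units; beyond the scatter), is larger than the one for methyl, an 8.0-fold lower number from compound 1 to compound 2 (0.90 log units; beyond the scatter). Nothing in hand bears on the origin of the difference between the two substituents.

The compounds shown cover only hydrogen, methyl and chloro at this position, so fluoro, bromo, methoxy and nitrile remain open as tests of how far this order extends. As far as these compounds go, all three also carry the same carboxymethoxy group, so it remains open whether the order among hydrogen, methyl and chloro would hold with a longer carboxylic acid chain in its place.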